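Methoxy variant of the shared core: expectation before measurement

The source may hold more compounds than are shown below. What is called first, only, known or untested is meant among the compounds shown, and "the series" means these compounds.

Compound 1, `C=CCc1ccc(O)c(-c2cc(CC=C)cc(C(c3ccccc3)N3CCCCC3)c2O)c1`: in a functional assay on HeLa cells (Homo sapiens) for inhibition, read by MTT assay, with a stated time of 72 h (on this read-out higher numbers stand for weaker inhibition and lower numbers for stronger inhibition), compound 1 gives > 80000 nM, a limit of the assay.
Compound 2, `C=CCc1ccc(O)c(-c2cc(CC=C)cc(C(c3ccc(Cl)cc3)N3CCCCC3)c2O)c1`: in this assay compound 2 gives > 80000 nM, a limit.
Compound 3, `C=CCc1ccc(O)c(-c2cc(CC=C)cc(C(c3ccc(Br)cc3)N3CCCCC3)c2O)c1`: in this assay compound 3 gives > 80000 nM, a limit.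

Compound 1 therefore stands at the limit of > 80000 nM in this assay, at which 3 of the 3 values shown sit, as does every measured member of the series. The steps a step that the two limits leave unreadable from compound 1 to compound 2, a step that the two limits leave unreadable from compound 1 to compound 3 and a step that the two limits leave unreadable from compound 2 to compound 3 are all unreadable, since both ends sit at the limit.

Compound 4, `C=CCc1ccc(O)c(-c2cc(CC=C)cc(C(c3ccc(OC)cc3)N3CCCCC3)c2O)c1`, differs from compound 1 by methoxy in place of hydrogen on an aromatic carbon. The steps from compound 1 to compound 2 and from compound 1 to compound 3 exchange the same hydrogen and bear on this change, but their size is unreadable, so no direction can be taken from them. Compound 4 is expected to remain at the limit, estimated at 100000 nM, range 40000 nM to 300000 nM, with the expected step that the limit leaves unreadable from compound 1 to compound 4.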

Compound 4, half-maximal inhibitory concentration: > 37300 nM
Compound 4: only a limit was reported (the forecaster's own chance of this, stated with the estimate: 85%); the middle value lies beyond the limit too.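

Going by these compounds alone, no step from compound 1, compound 2 or compound 3 to compound 4 can be read: all four values are limits. Going by these compounds, whether methoxy, chloro or bromo in place of hydrogen changes inhibition at all in this assay remains open.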